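Aryloxypropanolamine series: squalene synthase inhibition, from carbonyl to ether

The source may report more compounds than this note shows. Statements on the series, on what has been measured and on what is new or still open speak of the compounds shown alone.

Three compounds carry numbers in an assay for inhibition of squalene synthase (Rattus norvegicus), using microsomes; a lower number here means a stronger inhibitor, a higher number a weaker inhibitor. Compound 1 `CCC(=O)Nc1ccc(OCC(O)CNC(C)C)c(Cc2ccccc2)c1` gives 900 nM. Compound 2 `C=CCc1cc(C(=O)CCC)ccc1OCC(O)CNC(C)C` gives 4.5 nM. Compound 3 `C=CCc1cc(C(=O)CCC)ccc1OCCCNC(C)C` gives 1 nM, the lowest of the three numbers; the nearest is compound 2, the furthest compound 1. Among the compounds with values here, the single one-place step measured so far is a 4.5-fold lower number from compound 2 to compound 3 (0.65 log units; beyond the scatter), which concerns the chain between the phenoxy oxygen and the isopropylamine.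

Compound 4 `C=CCc1cc(OCCCC)ccc1OCCCNC(C)C` is not yet measured. It differs from compound 3 by butoxy in place of propylcarbonyl on an aromatic carbon. Within the data shown here, no measured step touches this position or exchanges a propylcarbonyl for an ether; the only step on record, from compound 2 to compound 3, alters another part of the molecule and gives no guidance here. The expectation for compound 4 therefore rests on compound 3 alone, and its number in this assay is estimated at 4 nM, within 0.8 nM to 30 nM. This corresponds to an expected step of a 4.0-fold higher number from compound 3 to compound 4 (0.60 log units; beyond the scatter), a change that may well fall within the scatter, with the direction left open until the measurement is made.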

Compound 4, half-maximal inhibitory concentration: 0.6 nM
Beside the measured number, compound 4's estimate is 6.7-fold (0.82 log units) above it; measured number below the stated range.
By their numbers in this assay, from the lowest: compounds 4 and 3 (each within the scatter of the next); then compound 2; then compound 1.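

In this assay, butoxy in place of propylcarbonyl on this aromatic carbon gives a 1.7-fold lower number from compound 3 to compound 4 (0.22 log units; within the scatter), so the two groups cannot be told apart at this position. The carbonyl of the propylcarbonyl group is therefore not needed for a low number on this core: compound 4, which has butoxy at that place, reads 0.6 nM. No supporting data are available to explain why the two groups read alike.

On these data alone, this exchange is read only with the chain of compound 3, so whether it gives the same result with the hydroxy-bearing chain of compound 2 remains open. Also open, as far as these compounds go, is how an amine, a carboxylic acid or an alkoxy chain longer than butoxy would read at this aromatic carbon.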